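A few compounds are considered here, and "the series" means these few. Any claim that something is new, unique, unknown or untested is made for them only; others in the source may bear on it.

Measured in a functional assay on CCRF-CEM cells (Homo sapiens) for inhibition; a higher number here means a weaker inhibitor, a lower number a stronger inhibitor:
- Compound 1 `O=C1CCCCC/C1=C\c1ccc(Br)cc1`: 42800 nM
- Compound 2 `Cc1ccc(/C=C2\CCCCCC2=O)cc1`: > 500000 nM (a limit of the assay, not a number)
- Compound 3 `COc1ccc(/C=C2\CCCCCC2=O)cc1`: 194000 nM

Compound 3, at 194000 nM, has the higher of the two actual numbers, which makes it a weaker inhibitor in this assay than compound 1. Compound 2 gives only a limit, > 500000 nM.

The next structure is compound 4 `CN(C)c1ccc(/C=C2\CCCCCC2=O)cc1`, which carries dimethylamino in place of methoxy on an aromatic carbon.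

Within the data shown here, no measured step involves dimethylamino, but three steps changed the group at this same place. With methyl in place of bromo, the change was large: an at least 11-fold higher number from compound 1 to compound 2 (1.06 log units; beyond the scatter). With methoxy in place of bromo, it was modest: a 4.5-fold higher number from compound 1 to compound 3 (0.66 log units; beyond the scatter). With methoxy in place of methyl, it was at least modest: an at least 2.5-fold lower number from compound 2 to compound 3 (0.41 log units; beyond the scatter). All three lie beyond the scatter, so exchanging the group here can clearly move the number, but these steps do not settle the direction for dimethylamino. A small shift is therefore expected, with a wide margin on either side.

The expected step is a 1.3-fold lower number from compound 3 to compound 4 (0.11 log units; within the scatter).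

For compound 4, the estimated value is 150000 nM, with an expected range from 40000 nM to 500000 nM.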

Compound 4, half-maximal inhibitory concentration: 45100 nM
Compound 4: the middle estimate sits 3.3-fold (0.52 log units) above what was measured, within the range that was stated.
By their numbers in this assay, from the lowest: compounds 1 and 4 (each within the scatter of the next); then compound 3. At a limit, above all of these: compound 2.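

In this assay, exchanging methoxy for dimethylamino gives a 4.3-fold lower number from compound 3 to compound 4 (0.63 log units; beyond the scatter), which shows that a group holding nitrogen can bring the number down at this place on the ring. The earlier compounds shown here showed only a rise on leaving bromo, whereas compound 4 shows that leaving bromo need not cost anything, with a 1.1-fold higher number from compound 1 to compound 4 (0.02 log units; within the scatter), so bromo and dimethylamino cannot be told apart here. Compound 2 has only a limit of the assay rather than a true number, so an at least 11-fold lower number from compound 2 to compound 4 (1.04 log units; beyond the scatter) is a bound on the gap between methyl and dimethylamino, not its exact size: the limit of > 500000 nM in this assay, at which 1 of the 4 values shown sits.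

The compounds shown leave open whether other nitrogen groups at this place, such as a plain amine or diethylamino, would stay level with compound 4, and whether chloro or fluoro would stay level with compound 1. They also leave open whether the same order among these groups would hold on a different core, or with the group placed elsewhere on the aromatic ring.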